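The source may hold more compounds than are shown below. What is called first, only, known or untested is meant among the compounds shown, and "the series" means these compounds.

Compound 1 `Cc1ccc(-c2cc(/N=C3/NC(=O)CS3)cs2)cc1` and compound 2 `COc1ccc(-c2cc(/N=C3/NC(=O)CS3)cs2)cc1` share one core; compound 3 `COc1ccc(/C=C2\S/C(=N\c3csc(-c4ccc(Cl)cc4)c3)NC2=O)cc1` has a larger core, and the difference between the two cores is not broken down here. In a functional assay on MCF7 cells (Homo sapiens) for cytotoxicity, read by MTT assay, with a stated time of 72 h (a lower number here means a stronger inhibitor, a higher number a weaker inhibitor), compound 1 gives a value that is a limit of the assay, > 50000 nM. Compound 2 also gives only a limit in this assay, > 50000 nM. Among the compounds with values here, compound 3 gives 1000 nM in this assay, the only number among the three. The change from compound 2 to compound 1, (methyl in place of methoxy on an aromatic carbon), made a step that the two limits leave unreadable from compound 2 to compound 1, because both values sit at the limit of > 50000 nM in this assay, at which 2 of the 3 values shown sit. Compound 4 `Cc1ccc(/C=C2\S/C(=N\c3csc(-c4ccc(Cl)cc4)c3)NC2=O)cc1` is not yet measured; it differs from compound 3 by the same change, (methyl in place of methoxy on an aromatic carbon). Since the earlier step from compound 2 to compound 1 is unreadable, nothing here shows the size this change makes, so a small step from compound 3 to compound 4 is expected, a 1.3-fold higher number from compound 3 to compound 4 (0.11 log units; within the scatter). Compound 4 is therefore estimated at 1300 nM in this assay, between 400 nM and 4500 nM.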

Compound 4, half-maximal inhibitory concentration: 900 nM
For compound 4 the middle estimate is 1.4-fold (0.16 log units) above the measured one; the range from low to high includes it.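

In this assay, methyl in place of methoxy on the larger core gives a 1.1-fold lower number from compound 3 to compound 4 (0.05 log units; within the scatter), so on this core the swap leaves the number indistinguishable from repeat-measurement noise. The same swap from compound 2 to compound 1 cannot be read, as both compounds sit at a limit of the assay rather than at a number: the limit of > 50000 nM in this assay, at which 2 of the 4 values shown sit. Within the data shown here, the change is therefore readable on only one core, and nothing here shows whether its size carries from one core to the other.

The compounds shown leave open what an amine, a carboxylic acid or a longer chain at this same place would do on the larger core. They also leave open which part of the larger core goes with the measurable numbers of compound 3 and compound 4.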